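A few compounds are considered here, and "the series" means these few. Any claim that something is new, unique, unknown or untested is made for them only; others in the source may bear on it.

Measured in a functional assay on A549 cells (Homo sapiens) for cytotoxicity, read by sulforhodamine B assay, with a stated time of 48 h; on this read-out lower numbers stand for stronger inhibition and higher numbers for weaker inhibition:
- compound 1 `COc1ccc(/C=C/C(=O)c2cccc(-c3ccc(F)cc3)c2)cc1`: 11200 nM
- compound 2 `COc1cccc(/C=C/C(=O)c2cccc(-c3cccc(F)c3)c2)c1OC`: 8900 nM

In this assay, compound 2 at 8900 nM lies within the scatter of compound 1 at 11200 nM, so the two numbers set no order.

Next is compound 3 `COc1ccccc1/C=C/C(=O)c1cccc(-c2cccc(F)c2)c1`, which differs from compound 2 by one change: hydrogen in place of methoxy on an aromatic carbon. This puts hydrogen in place of methoxy on an aromatic carbon. Within the data shown here, no step between measured compounds isolates this change, so the expectation rests only on the closeness of the two values in hand. The expected result, a 1.1-fold higher number from compound 2 to compound 3 (0.05 log units; within the scatter), is a step no larger than the scatter, with no direction favoured. For compound 3 the estimated value is 10000 nM. The expected range for compound 3 runs from 4500 nM to 22000 nM.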

Compound 3, half-maximal inhibitory concentration: 15500 nM
For compound 3 the middle estimate is 1.6-fold (0.19 log units) below the measured one, within the range that was stated.
By their numbers in this assay, from the lowest: compounds 2, 1 and 3 (each within the scatter of the next).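

In this assay, among these compounds, hydrogen in place of methoxy gives a 1.7-fold higher number from compound 2 to compound 3 (0.24 log units; within the scatter) and is the only step in this set that isolates a single change. At this position on the aromatic ring, ortho to a methoxy group and meta to a large group, the methoxy group can therefore give way to hydrogen with no step beyond the scatter, so the two compounds are not separated by this assay. No measurement at hand accounts for the step or ties it to any property of the group.

As far as these compounds go, whether an amine, a hydroxyl group or a longer alkoxy chain at this position would give a step beyond the scatter remains open. Compound 1 differs from compound 2 and compound 3 in more than one place, so the role of the fluorine position on the second aromatic ring also remains unresolved.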